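The compounds below may be only part of what the source reports. "The series", "measured", "known", "first", "only" and "open" are said of these compounds alone.

Working notes on the series, step from compound 2 to compound 4.

Three compounds have numbers in an ADME assay on MT2 cells (Homo sapiens) for cytotoxicity, read by MTT assay; a lower number here means that less compound is tolerated, a higher number that more compound is tolerated. Compound 1 `Fc1cccc(F)c1Cc1cnc(Nc2ccc(Oc3cccnc3)c(Cl)c2)o1` gives 16000 nM. Compound 2 `[O-][n+]1ccc(OCc2ccc(Nc3ncc(Cc4c(F)cccc4F)o3)cc2Cl)cc1` gives 1700 nM and stands lowest of the three: compound 1 is its nearest neighbour, and compound 3 `Clc1cccc(Cl)c1Cc1nnc(Nc2ccc(COCc3ccccc3)cc2)o1`, with 84000 nM, is the furthest. Among the compounds with values here, the single step that changes one place is a 9.4-fold lower number from compound 1 to compound 2 (0.97 log units; beyond the scatter).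

Compound 4 `Fc1cccc(F)c1Cc1cnc(Nc2ccc(COc3ccncc3)c(Cl)c2)o1` is not yet measured in this assay. It differs from compound 2 only in the group that carries the oxygen on the saturated carbon: a group of 6 heavy atoms (5 carbon, 1 nitrogen; one six-membered aromatic ring with 1 hetero atom) in place of a group of 7 heavy atoms (5 carbon, 1 nitrogen, 1 oxygen; one six-membered aromatic ring with 1 hetero atom), on an oxygen on a saturated carbon. A pyridin-4-yl thus takes the place of the group of 7 heavy atoms with one oxygen.

Within the data shown here, the only measured step that bears on this change is the one from compound 1 to compound 2, which brought the group of 7 heavy atoms in and lowered the number. Taking it out again in compound 4 is expected to move the number partly back toward compound 1, beyond the scatter but not the full way; the expected step is a 2.9-fold higher number from compound 2 to compound 4 (0.47 log units; beyond the scatter). Compound 4 is therefore estimated at 5000 nM, within 2000 nM to 15000 nM.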

Compound 4, half-maximal cytotoxic concentration: 3800 nM
Estimate against measurement, compound 4: 1.3-fold (0.12 log units) above; measured number inside the range.
By their numbers in this assay, from the lowest: compound 2; then compound 4; then compound 1; then compound 3.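

In this assay the change at the oxygen on a saturated carbon is a step of its own: pyridin-4-yl gives a 2.2-fold higher number from compound 2 to compound 4 (0.35 log units; beyond the scatter) and so moves the number at this place without any change in the core. The other step, a 4.2-fold lower number from compound 1 to compound 4 (0.62 log units; beyond the scatter) with ((pyridin-4-yl)oxy)methyl in place of (pyridin-3-yl)oxy on an aromatic carbon, shows that a lower number than that of compound 1 does not depend on the group of 7 heavy atoms, with compound 4 standing between compound 1 and compound 2. Nothing measured here gives a reason for either step.

Still open, as far as these compounds go, is how far the number moves at this place with a non-aromatic group there, such as a primary amine or a carboxylic acid. From the compounds shown here alone, whether pyridin-4-yl gives the same step on the core of compound 3 also remains unknown.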